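This account rests on a few compounds, and the source may have more. Where it says the series, first, only, none or still open, it means among the compounds named here.

In an ADME assay on microsomes from liver (Homo sapiens) for metabolic stability, with a stated time of 10 min (a higher number here means that more of the compound is left, a lower number that less of the compound is left), compound 2 (`O=C(O)[C@H]1CC[C@H](C(=O)N2CC[C@](c3ccc(C(OCC4CCC4)(C(F)(F)F)C(F)(F)F)cc3)(S(=O)(=O)c3ccc(F)cc3)C2)CC1`) gives 85% and compound 1 (`Cc1cccc(F)c1COC(c1ccc([C@]2(S(=O)(=O)c3ccc(F)cc3)CCN(C(=O)[C@H]3CC[C@H](C(=O)O)CC3)C2)cc1)(C(F)(F)F)C(F)(F)F`) gives 79%, so the two cannot be told apart. Compound 3 (`O=C(O)[C@H]1CC[C@H](C(=O)N2CC[C@](c3ccc(C(OCC4CCCCC4)(C(F)(F)F)C(F)(F)F)cc3)(S(=O)(=O)c3ccc(F)cc3)C2)CC1`) has not yet been measured. It differs from compound 2 in one place, on a saturated chain carbon bound to an oxygen on a saturated carbon, where cyclohexyl stands in place of cyclobutyl: cyclohexyl in place of cyclobutyl on a saturated chain carbon bound to an oxygen on a saturated carbon. Among the measured compounds shown here, only one measured step bears on this change, the exchange of 2-fluoro-6-methylphenyl for cyclobutyl at that same place. Because that exchange gave a number 6 percentage points higher from compound 1 to compound 2 (within the scatter), no step beyond the scatter is expected in this assay, although a single step is thin evidence. The estimated step is a number 4 percentage points lower from compound 2 to compound 3 (within the scatter). For compound 3 the expected value is 81%, with an estimated range from 65% to 93%.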

Compound 3, percent of the compound remaining: 92%
Compound 3: middle estimate off by 11 percentage points, on the low side, within the range that was stated.
By their numbers in this assay, from the lowest: compounds 1, 2 and 3 (each within the scatter of the next, the first and the last beyond it).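

In this assay, cyclohexyl in place of cyclobutyl on a saturated chain carbon bound to an oxygen on a saturated carbon gives a number 7 percentage points higher from compound 2 to compound 3 (within the scatter), so a six-membered ring and a four-membered ring cannot be told apart at this place. Cyclohexyl in place of 2-fluoro-6-methylphenyl gives a number 13 percentage points higher from compound 1 to compound 3 (beyond the scatter), a modest step and the first change at this place to pass the scatter, while compound 2 stays within the scatter of both other compounds. Nothing available here explains this difference between the cyclohexyl and 2-fluoro-6-methylphenyl groups.

The compounds shown leave open whether a ring containing an oxygen, such as tetrahydropyranyl, or an open hexyl chain would give a similar number at this place. They also leave open what an amine on the cyclohexyl ring would do.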